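Chain extension of a hydroxamate beyond an unreadable limit

The compounds below may be only part of what the source reports. "The series", "measured", "known", "first", "only" and "open" are said of these compounds alone.

Compound 1 `O=C(CCCCCC(=O)Nc1nnc(-c2ccncc2)s1)NO` in a functional assay on K562 cells (Homo sapiens) for antiproliferative activity, read by MTT assay, with a stated time of 48 h (a higher number here means a weaker inhibitor, a lower number a stronger inhibitor), reaches only the limit, > 60000 nM.
Compound 2 `O=C(CCCCCC(=O)Nc1nnc(-c2cccs2)s1)NO` in this assay reaches only the limit, > 60000 nM.
Compound 3 `O=C(CCCCCC(=O)Nc1nnc(-c2cccnc2)s1)NO` in this assay reaches only the limit, > 60000 nM.

All three measured compounds share one core and differ only in the aromatic group attached to it. None of them yields a number: every value is a limit of this assay (the limit of > 60000 nM in this assay, at which 3 of the 3 values shown sit). The steps between them, a step that the two limits leave unreadable from compound 1 to compound 2, a step that the two limits leave unreadable from compound 1 to compound 3 and a step that the two limits leave unreadable from compound 2 to compound 3, are therefore unreadable, and compound 3 stands at the limit with nothing to set it apart from compound 1 or compound 2.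

Compound 4 `O=C(CCCCCCC(=O)Nc1nnc(-c2cccnc2)s1)NO` keeps the aromatic group of compound 3 and alters the chain instead: (hydroxycarbamoyl)methyl in place of hydroxycarbamoyl on a saturated chain carbon, five bonds along the chain from a carbonyl carbon. Among the measured compounds shown here, no measured step concerns the chain, so nothing in the data speaks to this change directly. With all three measured values sitting at the limit, the step that the limit leaves unreadable from compound 3 to compound 4 is expected to leave compound 4 at or near that limit as well. Compound 4 is therefore expected to give about 80000 nM in this assay, within a range of 20000 nM to 300000 nM, most likely as a limit rather than a number.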

Compound 4, half-maximal inhibitory concentration: 4360 nM
The estimate for compound 4 lay 18-fold (1.26 log units) above the measured number, outside the stated range (below it).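

Among the compounds shown here, the chain, which no earlier step touched, proves to be a position where a single change can be read: with (hydroxycarbamoyl)methyl in place of hydroxycarbamoyl on a saturated chain carbon, five bonds along the chain from a carbonyl carbon, this assay shows an at least 13-fold lower number from compound 3 to compound 4 (1.13 log units; beyond the scatter), which lies beyond the scatter. Compound 4 is the only one of the four compounds shown that gives a number rather than a limit, so the series now has one value against which further changes could be read. The step can be stated only as a minimum, since it starts from a limit rather than a number: the limit of > 60000 nM in this assay, at which 3 of the 4 values shown sit.

From the compounds shown here alone, the steps among compound 1, compound 2 and compound 3 still cannot be read, and it remains open whether pyridin-4-yl or thiophen-2-yl would give a number on the chain of compound 4. Also open, going by these compounds, is whether a longer chain, such as 2-(hydroxycarbamoyl)ethyl in place of (hydroxycarbamoyl)methyl, would lower the number further, and whether a carboxylic acid or an amine at the chain end could stand in for the hydroxycarbamoyl group.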